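The source may hold more compounds than are shown below. What is called first, only, known or untested is meant among the compounds shown, and "the series" means these compounds.

For the measured compounds named here, in an ADME assay on microsomes from liver (Canis lupus familiaris) for metabolic stability, with a stated time of 10 min (on this read-out higher numbers stand for a more stable compound and lower numbers for a less stable compound), compound 1 (`FC(F)(F)c1ccccc1-c1ccc2[nH]c(C3=NOC4(CCCCC4)C3)nc2c1`) gives 71% and compound 2 (`Fc1cccc(C(F)(F)F)c1-c1ccc2[nH]c(C3=NOC4(CCCCC4)C3)nc2c1`) gives 65% with the two lying within the scatter of each other, so compound 1 stands level with the only other compound measured. Compound 3 (`Fc1cc(-c2ccccc2C(F)(F)F)cc2nc(C3=NOC4(CCCCC4)C3)[nH]c12`) departs from compound 1 in a single change (fluoro in place of hydrogen on an aromatic carbon) on an aromatic carbon of a six-membered aromatic ring of carbon only, ortho to a fused ring and meta to a 2-(trifluoromethyl)phenyl group. Going by the values given here, one measured step bears on it, the same exchange of fluoro in place of hydrogen made at a different place (a number 6 percentage points lower from compound 1 to compound 2 (within the scatter)) and that step stayed within the scatter. Among the compounds with values here, no measurement yet shows fluoro at the place it takes in compound 3, so this guide is only indirect. With compound 2 at 65% as the one reference, no step beyond the scatter is expected in this assay and any drift is expected to be slightly downward. The expected step (a number 5 percentage points lower from compound 1 to compound 3 (within the scatter)) stays inside the scatter. Compound 3 is therefore estimated at 66% with an expected range from 52% to 79% on this read-out.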

Compound 3, percent of the compound remaining: 87%
Beside the measured number, compound 3's estimate is 21 percentage points below it; measured number above the stated range.
By their numbers in this assay, from the lowest: compounds 2 and 1 (each within the scatter of the next); then compound 3.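

In this assay, fluoro in place of hydrogen on an aromatic carbon of the fused system, ortho to a fused ring and meta to a 2-(trifluoromethyl)phenyl group, gives a number 16 percentage points higher from compound 1 to compound 3 (beyond the scatter) and takes compound 3 to 87% on this read-out. The same exchange at a different place gave a number 6 percentage points lower from compound 1 to compound 2 (within the scatter) and did not leave the scatter, so across these two steps the outcome of adding one fluoro differs with its place on the compound, and only the place it takes in compound 3 gives a modest rise beyond the scatter. Nothing available explains this rise or says what the added fluoro does at this carbon.

The compounds shown leave open whether the rise belongs to fluoro in particular or would also appear with chloro, methoxy or an amine on the same aromatic carbon. They also leave open whether this step would hold on a core that carries something other than the 2-(trifluoromethyl)phenyl group, and whether it would carry over to a longer incubation or to microsomes from another species.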